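Chloro in Place of Nitro: What to Expect for Compound 4

The compounds below may be only part of what the source reports. "The series", "measured", "known", "first", "only" and "open" are said of these compounds alone.

Of the compounds shown here, three of one family have been measured in an assay on isolated protein for inhibition of Amine oxidase [flavin-containing] B (Homo sapiens), read by Amplex Red, with a stated time of 15 min; on this read-out higher numbers stand for weaker inhibition and lower numbers for stronger inhibition. Compound 1 `CC(=O)c1ccc(OCc2ccc(C)cc2)cc1` gives 102 nM, compound 2 `CC(=O)c1ccc(OCc2ccc([N+](=O)[O-])cc2)cc1` gives 96.5 nM, and compound 3 `CC(=O)c1ccc(OCc2ccccc2F)cc1` gives 56.9 nM. Compound 2 holds the second highest of the three numbers; its nearest neighbour is compound 1, and all three values lie within the usual scatter of one another, so no ranking can be drawn from them. Within the data shown here, the single measured step that changes one group, a 1.1-fold lower number from compound 1 to compound 2 (0.02 log units; within the scatter), swapped a methyl for a nitro and left the number essentially where it was. Compound 4 `CC(=O)c1ccc(OCc2ccc(Cl)cc2)cc1` has not yet been measured; it differs from compound 2 by chloro in place of nitro on an aromatic carbon. The step from compound 1 to compound 2 bears on this change only loosely, since it exchanged two other groups at the same site and stayed within the scatter. Among the measured compounds shown here, no measured step shows a chloro entering there. The expected step is therefore a 1.2-fold lower number from compound 2 to compound 4 (0.08 log units; within the scatter), small and without a firm direction. Compound 4 is thus estimated to give about 80 nM in this assay, with a likely range from 35 nM to 200 nM.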

Compound 4, half-maximal inhibitory concentration: 63.2 nM
Estimate against measurement, compound 4: 1.3-fold (0.10 log units) above, within the range that was stated.
By their numbers in this assay, from the lowest: compounds 3, 4, 2 and 1 (each within the scatter of the next).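

In this assay three different groups have now been read on the same aromatic carbon, para to a large group: methyl, nitro and chloro. Replacing the nitro, with its 3 heavy atoms, by the single heavy atom of chloro gives a 1.5-fold lower number from compound 2 to compound 4 (0.18 log units; within the scatter) and replacing methyl by chloro gives a 1.6-fold lower number from compound 1 to compound 4 (0.21 log units; within the scatter) so this position has not yet separated these three groups from one another. Nothing measured on these compounds explains why the three read alike. Still open, from the compounds shown here alone, is whether a group of another kind at this position, such as an amine, a carboxylic acid or a longer chain, would move the number beyond the scatter. Also open, going by these compounds, is whether chloro would read the same on another carbon of this ring.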